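The source may report more compounds than this note shows. Statements on the series, on what has been measured and on what is new or still open speak of the compounds shown alone.

In a functional assay on K562 cells (Homo sapiens) for antiproliferative activity, read by MTT assay (on this read-out higher numbers stand for weaker inhibition and lower numbers for stronger inhibition), compound 1 (`O=C(CCCCCNC(=S)NN=C(c1ccccn1)c1ccccn1)NO`) gives 2870 nM as its result, and compound 2 (`C/C(=N\NC(=S)NCCCCCC(=O)NO)c1ccc(F)cc1`) gives 1890 nM as its result. Compound 3 (`C/C(=N\NC(=S)NCCCCCC(=O)NO)c1cccc(Br)c1`) gives 1260 nM on the same read-out. That value lies within the scatter of compound 2, while compound 1 has a higher number than compound 3 by more than the scatter.

Compound 4 (`C/C(=N\NC(=S)NCCCCCC(=O)NO)c1cccc(C)c1`) has not been measured yet. It differs from compound 3 in one place (methyl in place of bromo on an aromatic carbon): methyl in place of bromo on an aromatic carbon, meta to a large group.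

Among the compounds with values here, only one measured step changes a substituent on this ring, and it is a 1.5-fold lower number from compound 2 to compound 3 (0.18 log units; within the scatter) in size. Swapping the 4-fluorophenyl for the 3-bromophenyl there stayed within the scatter, so no shift beyond the scatter is expected here, in either direction. The expected change is a 1.2-fold higher number from compound 3 to compound 4 (0.08 log units; within the scatter) and it remains a small one. The estimated value for compound 4 is 1500 nM with an expected range from 750 nM to 3000 nM on repeated measurement.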

Compound 4, half-maximal inhibitory concentration: 3840 nM
For compound 4 the middle estimate is 2.6-fold (0.41 log units) below the measured one; the measured number lies above the stated range.
By their numbers in this assay, from the lowest: compounds 3, 2, 1 and 4 (each within the scatter of the next, the first and the last beyond it).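

In this assay this ring position proves sensitive to the exchange of one heavy atom for another: there is a 3.0-fold higher number from compound 3 to compound 4 (0.48 log units; beyond the scatter) even though bromo and methyl match in heavy-atom count, and neither has hydrogen-bond donors, acceptors or a net charge. Within the data shown here, the only earlier step on this ring stayed within the scatter, so this is the first sign that the substituent can shift the result, and the 3-methylphenyl group also shows a 2.0-fold higher number from compound 2 to compound 4 (0.31 log units; beyond the scatter) when set against the 4-fluorophenyl group. Nothing available explains the difference between bromo and methyl.

The compounds shown leave open whether chloro, trifluoromethyl or an amine at this place would give a number closer to that of compound 3 or compound 4. On these data alone, it also remains open whether bromo would hold its result on another carbon of the ring.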